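Series notes: methoxy in place of bromo, compound 4 expected

A few compounds are considered here, and "the series" means these few. Any claim that something is new, unique, unknown or untested is made for them only; others in the source may bear on it.

Measured so far in a functional assay on MCF7 cells (Homo sapiens) for antiproliferative activity, read by MTT assay, with a stated time of 48 h; on this read-out higher numbers stand for weaker inhibition and lower numbers for stronger inhibition:
compound 1, `O=C(/C=C/c1ccc(F)cc1)Nc1nnc(-c2ccc(Cl)cc2)s1`, compound 1 gives 1.58 ug/mL
compound 2, `COc1ccc(-c2nnc(NC(=O)/C=C/c3ccc(C)cc3)s2)cc1`, compound 2 gives 0.31 ug/mL
compound 3, `O=C(/C=C/c1ccc(F)cc1)Nc1nnc(-c2ccc(Br)cc2)s1`, compound 3 gives 1.49 ug/mL

Compound 3 stands second highest of the three numbers. Its nearest neighbour is compound 1, and the step of a 1.1-fold lower number from compound 1 to compound 3 (0.03 log units; within the scatter) is within the scatter, so nothing separates the two. Compound 2 is the furthest away, with a number below compound 3 by a margin beyond the scatter.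

The unmeasured compound 4, `COc1ccc(-c2nnc(NC(=O)/C=C/c3ccc(F)cc3)s2)cc1`, differs from compound 3 by methoxy in place of bromo on an aromatic carbon. Among the measured compounds shown here, the one measured step, from chloro to bromo, does not touch this change and was within the scatter. Compound 2 does carry the 4-methoxyphenyl, but it differs from compound 3 in two places (methyl against fluoro on the other ring as well), so its number can only be read as suggestive: the methoxy-bearing compound gives the lowest number of the three. On that basis a step down is expected for compound 4, a 2.7-fold lower number from compound 3 to compound 4 (0.43 log units; beyond the scatter), taking compound 4 toward the value of compound 2 without assuming the second change contributes. Compound 4 is therefore estimated at 0.55 ug/mL, with a range from 0.22 ug/mL to 1.4 ug/mL.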

Compound 4, half-maximal inhibitory concentration: 0.85 ug/mL
Estimate against measurement, compound 4: 1.5-fold (0.19 log units) below, and the stated range covers the measured number.
By their numbers in this assay, from the lowest: compound 2; then compounds 4, 3 and 1 (each within the scatter of the next).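

With fluoro kept on the other aromatic ring, methoxy at this position is not separated from either halogen in this assay (a 1.8-fold lower number from compound 3 to compound 4 (0.24 log units; within the scatter)) and (a 1.9-fold lower number from compound 1 to compound 4 (0.27 log units; within the scatter)). Among the compounds shown here, the pair with methoxy held in place isolates the other ring for the first time, and fluoro in place of methyl gives the only new step beyond the scatter (a 2.7-fold higher number from compound 2 to compound 4 (0.44 log units; beyond the scatter)), so the low number of compound 2 cannot be credited to the 4-methoxyphenyl alone. No measurement bears on the reason for any of these steps.

On these data alone, whether the methyl step holds with bromo or chloro in place of methoxy stays open. Also open, as far as these compounds go, is how an amine or a carboxylic acid would read at this position.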